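Chain extension on the acetamide of compound 3

This account rests on a few compounds, and the source may have more. Where it says the series, first, only, none or still open, it means among the compounds named here.

Compound 1, `CCCCCCc1nc2ccccc2[nH]1`, compound 2, `CCCCCCCCCCCCCc1nc2ccccc2[nH]1`, and compound 3, `CC(=O)Nc1ccc2[nH]c(C)nc2c1`, have been measured in an ADME assay on microsomes from liver for inhibition of cytochrome P450 2B1 (Rattus norvegicus); on this read-out lower numbers stand for stronger inhibition and higher numbers for weaker inhibition. Compound 1 gives 32400 nM, compound 2 gives 22900 nM and compound 3 gives 1260000 nM, the highest of the three numbers; the gaps from compound 3 to compound 1 and to compound 2 both lie beyond the scatter. Compound 4, `CCCCC(=O)Nc1ccc2[nH]c(C)nc2c1`, differs from compound 3 by propyl in place of hydrogen on a saturated chain carbon bound to a carbonyl carbon. Among the measured compounds shown here, the one measured step that bears on lengthening a saturated chain is a 1.4-fold lower number from compound 1 to compound 2 (0.15 log units; within the scatter), which stayed within the scatter. A comparable outcome is therefore expected for compound 4 in this assay, the step of a 1.4-fold lower number from compound 3 to compound 4 (0.15 log units; within the scatter) being expected to stay small. Compound 4 is estimated at 900000 nM, with a range from 300000 nM to 2500000 nM.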

Compound 4, half-maximal inhibitory concentration: 417000 nM
Beside the measured number, compound 4's estimate is 2.2-fold (0.33 log units) above it; measured number inside the range.
By their numbers in this assay, from the lowest: compounds 2 and 1 (each within the scatter of the next); then compound 4; then compound 3.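

In this assay propyl in place of hydrogen on a saturated chain carbon bound to a carbonyl carbon gives a 3.0-fold lower number from compound 3 to compound 4 (0.48 log units; beyond the scatter) and so passes beyond the scatter, whereas a 1.4-fold lower number from compound 1 to compound 2 (0.15 log units; within the scatter) on the other chain stayed within it. This place therefore responds to added chain, though the step is modest. No accompanying measurement accounts for this step.

As far as these compounds go, whether a longer chain at this place lowers the number further remains open. So does whether an amine or a carboxylic acid at the chain end would match propyl.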